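A few compounds are considered here, and "the series" means these few. Any claim that something is new, unique, unknown or untested is made for them only; others in the source may bear on it.

Measured so far:
Compound 1 `CCCOC(=O)Nc1ccc(S(=O)(=O)N2C[C@H](c3ccccc3)NC2=O)cc1CC`: 60 nM
Compound 2 `CCc1cc(S(=O)(=O)N2C[C@H](c3ccccc3)NC2=O)ccc1NC(=O)c1ccc(N)cc1`: 220 nM
Compound 3 `CCOC(=O)Nc1ccc(S(=O)(=O)N2C[C@H](c3ccccc3)NC2=O)cc1C`: 50 nM

In a functional assay on A549 cells (Homo sapiens) for cytotoxicity, read by MTT assay (a higher number here means a weaker inhibitor, a lower number a stronger inhibitor), compound 2 gives the highest of the three numbers, so it is the weakest inhibitor here; compound 3, a carbamate, gives 50 nM, and compound 1, also a carbamate, gives 60 nM. Compound 4 `CCc1cc(S(=O)(=O)N2C[C@H](c3ccccc3)NC2=O)ccc1NC(=O)OC(C)C` differs from compound 2 in one place: isopropoxy in place of 4-aminophenyl on a carbonyl carbon. Within the data shown here, the only measured step of this kind, a 3.7-fold higher number from compound 1 to compound 2 (0.56 log units; beyond the scatter), runs the opposite way, from an alkoxy carbamate to the 4-aminophenyl amide, and was beyond the scatter. Because a 3.7-fold higher number from compound 1 to compound 2 (0.56 log units; beyond the scatter) undoes that change, compound 4 is expected to fall back toward the carbamate values, a modest step down, a 3.4-fold lower number from compound 2 to compound 4 (0.53 log units; beyond the scatter). Compound 4 is therefore estimated at 65 nM, with a range of 30 nM to 150 nM.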

Compound 4, half-maximal inhibitory concentration: 60 nM
Compound 4: the middle estimate sits 1.1-fold (0.03 log units) above what was measured, within the range that was stated.
By their numbers in this assay, from the lowest: compounds 3, 1 and 4 (each within the scatter of the next); then compound 2.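

In this assay, the loss seen with 4-aminophenyl on this carbonyl carbon is recovered when isopropoxy takes its place (a 3.7-fold lower number from compound 2 to compound 4 (0.56 log units; beyond the scatter)). Isopropyl in place of propyl on the oxygen next to the carbonyl group makes no difference that can be read (no change at the digits printed from compound 1 to compound 4 (within the scatter)), so these two alkoxy groups are not told apart here. Nothing available explains why the carbamates and the 4-aminophenyl amide differ.

Going by these compounds, it remains open whether a plain phenyl behaves like 4-aminophenyl, and whether methoxy or a longer chain on the oxygen would match isopropoxy.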